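This account rests on a few compounds, and the source may have more. Where it says the series, first, only, none or still open, it means among the compounds named here.

In an ADME assay on microsomes from liver (Canis lupus familiaris) for metabolic stability (a lower number here means that the compound disappears faster, a higher number that the compound lasts longer), compound 2 `Nc1nc(NCCNc2ncc(-c3ncc[nH]3)c(-c3ccc(F)cc3C(F)(F)F)n2)ccc1[N+](=O)[O-]` gives > 0.5 h, which is a limit of the assay and not a number. Compound 1 `Nc1nc(NCCNc2ncc(-c3ncc[nH]3)c(-c3ccc(Cl)cc3)n2)ccc1[N+](=O)[O-]` gives > 0.5 h, which is also a limit. The two compounds therefore stand at the same mark: the limit of > 0.5 h in this assay, at which 2 of the 2 values shown sit.

Compound 3 `Nc1nc(NCCNc2ncc(-c3ncc[nH]3)c(-c3ccc(Cl)cc3F)n2)ccc1[N+](=O)[O-]` keeps the shared core and changes one group: 4-chloro-2-fluorophenyl in place of 4-fluoro-2-(trifluoromethyl)phenyl on an aromatic carbon. Here, 4-chloro-2-fluorophenyl takes the place of 4-fluoro-2-(trifluoromethyl)phenyl on an aromatic carbon, ortho to a 1H-imidazol-2-yl group.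

Within the data shown here, only one measured step bears on this change: a step that the two limits leave unreadable from compound 1 to compound 2. It also swaps the group at this same place, but its size cannot be read, so it offers no measured size or direction to carry forward. Among the measured compounds shown here, it shows only that both of these groups leave the half-life at the same limit. On that thin basis, no step beyond the scatter is expected in this assay, and neither direction is favoured. The expected step is a step that the limit leaves unreadable from compound 2 to compound 3. For compound 3 the estimated half-life is 0.8 h, with an expected range from 0.4 h to 2 h, and another limit is a likely outcome.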

Compound 3, half-life: > 0.5 h
Compound 3 was reported as a limit (the forecaster's own chance of this, stated with the estimate: 75%); the middle value is on the limit's open side.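

Compound 3 joins compound 1 and compound 2 as a result reported only as a limit of the assay, so no step among these three compounds can be read: the limit of > 0.5 h in this assay, at which 3 of the 3 values shown sit.

As far as these compounds go, how long each of the three compounds really lasts in this assay, and whether the groups swapped at this place differ at all, stays open.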